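The source may hold more compounds than are shown below. What is called first, only, known or untested is meant among the compounds shown, and "the series" means these compounds.

Working notes on the series. In an in vitro functional assay on HEK ts201 cells for antagonist activity at Neuronal acetylcholine receptor; alpha4/beta2 (Homo sapiens), read by fluorescence and calcium flux (on this read-out lower numbers stand for stronger inhibition and higher numbers for weaker inhibition), compound 3 `CC1CC(=O)N(c2ccccc2C(=O)OCC2CCCN(CCCC3CCCCC3)C2)C1=O` gives 14500 nM. Compound 1 `CC1CC(=O)N(c2ccccc2C(=O)OCC2CCCN(CCCCOc3ccc(Cl)c(Cl)c3)C2)C1=O` gives 12300 nM and compound 2 `CC1CC(=O)N(c2ccccc2C(=O)OCC2CCCN(CCCCCOc3ccc(Cl)c(Cl)c3)C2)C1=O` gives 17400 nM, so compound 3 sits among three numbers that lie within the scatter of one another, as shown by a 1.2-fold higher number from compound 1 to compound 3 (0.07 log units; within the scatter), a 1.2-fold lower number from compound 2 to compound 3 (0.08 log units; within the scatter) and a 1.4-fold higher number from compound 1 to compound 2 (0.15 log units; within the scatter). Compound 4 `CC1CC(=O)N(c2ccccc2C(=O)OCC2CCCN(CCCCCOc3ccccc3)C2)C1=O` carries 2-phenoxyethyl in place of cyclohexyl on a saturated chain carbon, three bonds along the chain from an amine nitrogen in a ring. Going by the values given here, the step from compound 1 to compound 3 changed the same place from (3,4-dichlorophenoxy)methyl to cyclohexyl and stayed within the scatter; the step to compound 4 runs the other way, to a phenoxy-bearing chain without the two chlorines, and no measured pair covers exactly that. Expected for compound 4 therefore: no step beyond the scatter, a 1.0-fold lower number from compound 3 to compound 4 (0.02 log units; within the scatter). The estimate for compound 4 is 14000 nM, range 7000 nM to 28000 nM.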

Compound 4, half-maximal inhibitory concentration: 17000 nM
For compound 4 the middle estimate is 1.2-fold (0.08 log units) below the measured one; the range from low to high includes it.
By their numbers in this assay, from the lowest: compounds 1, 3, 4 and 2 (each within the scatter of the next).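

Phenyl in place of 3,4-dichlorophenyl on an oxygen on a saturated carbon gives a 1.0-fold lower number from compound 2 to compound 4 (0.01 log units; within the scatter), so the two chlorines can go without a step beyond the scatter. 2-Phenoxyethyl in place of cyclohexyl gives a 1.2-fold higher number from compound 3 to compound 4 (0.07 log units; within the scatter), and phenoxymethyl in place of 3,4-dichlorophenoxy gives a 1.4-fold higher number from compound 1 to compound 4 (0.14 log units; within the scatter), so aromatic and saturated carbon rings at this position, with or without chlorine, all stay within the scatter. No measurement offered here accounts for this lack of separation. On these data alone, whether an amine or a carboxylic acid on the phenyl, or a much shorter chain, would give a step beyond the scatter remains open.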